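Shortening the dichlorophenyl amide: one chlorine removed

This account rests on a few compounds, and the source may have more. Where it says the series, first, only, none or still open, it means among the compounds named here.

Compound 1 `Cn1c(Cc2nn(C)c(=O)c3ccccc23)nnc1SCCCC(=O)Nc1ccc(Cl)cc1Cl`: 9800 nM
Compound 2 `Cn1c(Cc2nn(C)c(=O)c3ccccc23)nnc1SCCCCCCCC(=O)Nc1ccc(Cl)cc1Cl`: 1900 nM
Compound 3 `Cn1c(Cc2nn(C)c(=O)c3ccccc23)nnc1SCCCCCCCCCCC(=O)Nc1ccc(Cl)cc1Cl`: 3300 nM

Three compounds sharing one core and one 2,4-dichlorophenyl amide were measured in an assay on isolated protein (Mus musculus) for inhibition of IL15-IL15 receptor (Homo sapiens), read by resazurin assay, with stated times of 30 min and 2.5 days; on this read-out higher numbers stand for weaker inhibition and lower numbers for stronger inhibition. Compound 1 gives 9800 nM, compound 2 gives 1900 nM and compound 3 gives 3300 nM. Compound 2 holds the lowest of these three numbers; its gap to compound 3 lies within the scatter, while its gap to compound 1 lies beyond it, so compound 2 is separated only from compound 1.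

Compound 4 `Cn1c(Cc2nn(C)c(=O)c3ccccc23)nnc1SCCCCCCCC(=O)Nc1ccc(Cl)cc1` differs from compound 2 in a single spot: hydrogen in place of chloro on an aromatic carbon. The chloro that leaves stands on an aromatic carbon of a six-membered aromatic ring of carbon only, ortho to a large group and meta to a chloro group; what stays is the 4-chlorophenyl amide on the unchanged chain. Going by the values given here, no measured pair shows what a change of this kind does here, so the expectation rests on compound 2 alone.

A modest loss is expected, about a 1.8-fold higher number from compound 2 to compound 4 (0.27 log units; within the scatter), possibly no more than the scatter. Compound 4 is therefore estimated at 3500 nM, with a range from 1200 nM to 10000 nM in this assay.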

Compound 4, half-maximal inhibitory concentration: 800 nM
For compound 4 the middle estimate is 4.4-fold (0.64 log units) above the measured one, outside the stated range (below it).
By their numbers in this assay, from the lowest: compound 4; then compounds 2 and 3 (each within the scatter of the next); then compound 1.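

In this assay, hydrogen in place of chloro on an aromatic carbon, ortho to a large group and meta to a chloro group, gives a 2.4-fold lower number from compound 2 to compound 4 (0.38 log units; beyond the scatter). This chloro is therefore not required at this spot: on this chain, the 4-chlorophenyl amide gives the lower number, and the 2,4-dichlorophenyl amide gives the higher one. Nothing available explains this step, and a single pair on a single chain cannot show how general it is.

The compounds shown leave open whether the same change would lower the number on the shorter chain of compound 1 or the longer chain of compound 3. They also leave open what the remaining chloro contributes, which a plain phenyl amide, or a methoxy or fluoro group in its place, could show.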